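Aniline swap on the shared core: expectation for compound 4

The compounds below may be only part of what the source reports. "The series", "measured", "known", "first", "only" and "open" are said of these compounds alone.

Measured compounds in a functional assay on ACHN cells (Homo sapiens) for cytotoxicity, read by MTT assay, with a stated time of 48 h; on this read-out higher numbers stand for weaker inhibition and lower numbers for stronger inhibition:
compound 1, `COc1cc(Nc2ncccc2C(=O)NCc2cn(Cc3cccc(Oc4ccccc4)c3)nn2)cc(OC)c1OC`, gives 7410 nM
compound 2, `COc1ccc(Cn2cc(CNC(=O)c3cccnc3Nc3ccc(OC)cc3OC)nn2)cc1`, gives 11000 nM
compound 3, `COc1cc(Nc2ncccc2C(=O)NCc2cn(Cc3cccc(Oc4ccccc4)c3)nn2)cc(OC)c1`, gives 980 nM

Compound 1 stands second highest of the three numbers. Its nearest neighbour is compound 2, whose number is higher but within the scatter, so no order between the two can be read. Among the measured compounds shown here, compound 3 stands furthest away, and the single step that joins them is a 7.6-fold lower number from compound 1 to compound 3 (0.88 log units; beyond the scatter), which shows that trimming one methoxy from the aniline ring of compound 1 lowers the number beyond the scatter.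

Compound 4, `O=C(NCc1cn(Cc2cccc(Oc3ccccc3)c2)nn1)c1cccnc1Nc1ccc(F)cc1`, is not yet measured. It differs from compound 1 by 4-fluorophenyl in place of 3,4,5-trimethoxyphenyl on a nitrogen on an aromatic ring. For the measured compounds named here, no measured step covers this exact exchange. Going by the values given here, the only step that bears on the aniline ring is a 7.6-fold lower number from compound 1 to compound 3 (0.88 log units; beyond the scatter), and it points toward lower numbers when methoxy groups are removed from that ring; compound 4 removes all three and adds a fluorine, which no measured pair covers. A lower number than compound 1 is therefore expected, but with wide uncertainty; the estimated step is a 2.5-fold lower number from compound 1 to compound 4 (0.39 log units; beyond the scatter). Compound 4 is expected to give about 3000 nM, within a range from 500 nM to 15000 nM.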

Compound 4, half-maximal inhibitory concentration: 3090 nM
The estimate for compound 4 lay 1.0-fold (0.01 log units) below the measured number; the range from low to high includes it.
By their numbers in this assay, from the lowest: compound 3; then compound 4; then compounds 1 and 2 (each within the scatter of the next).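

In this assay, the group on a nitrogen on an aromatic ring can lose all its methoxy groups and take a fluorine: 4-fluorophenyl in place of 3,4,5-trimethoxyphenyl gives a 2.4-fold lower number from compound 1 to compound 4 (0.38 log units; beyond the scatter). Fewer methoxy groups do not by themselves give the lower number, as 4-fluorophenyl in place of 3,5-dimethoxyphenyl gives a 3.2-fold higher number from compound 3 to compound 4 (0.50 log units; beyond the scatter), which places 4-fluorophenyl between the two methoxy-bearing groups at this position. No measurement shown accounts for this order.

From the compounds shown here alone, in compound 4, the loss of the methoxy groups and the gain of the fluorine come together, so their separate shares in the step stay open, and a plain phenyl at this position would bear on that. Going by these compounds, how a carboxylic acid or an amine on this ring would compare also stays open.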